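This account rests on a few compounds, and the source may have more. Where it says the series, first, only, none or still open, it means among the compounds named here.

The measured compounds:
compound 2 `N[C@H]1CC[C@H](Nc2c(C(=O)NCc3ccc(F)cc3)nc(Br)c3cccnc23)CC1`: 2000 nM
compound 1 `N[C@H]1CC[C@H](Nc2c(C(=O)NCc3ccco3)nc(Br)c3cccnc23)CC1`: "not determined" (no result reported)

Among the measured compounds shown here, in a functional assay on MCF7 cells (Homo sapiens) for cytotoxicity, read by MTT assay, with a stated time of 72 h (on this read-out higher numbers stand for weaker inhibition and lower numbers for stronger inhibition), compound 2 gives 2000 nM, and this is the only number available. For compound 1 no result was reported, so compound 2 stands alone and can be ranked against nothing else.

Compound 3 `CN(C)c1ccc(CNC(=O)c2nc(Br)c3cccnc3c2N[C@H]2CC[C@H](N)CC2)cc1` differs from compound 2 in one place: dimethylamino in place of fluoro on an aromatic carbon. For the measured compounds named here, no measured pair shows a change of this kind, so there is nothing to set a size against it. Fluoro leaving and dimethylamino entering on that ring could move the reading in either direction, and with no evidence pointing one way, the expectation is for a step that stays within the usual scatter, a 1.3-fold higher number from compound 2 to compound 3 (0.10 log units; within the scatter) being the estimated shift from the value of compound 2. Compound 3 is therefore estimated at 2500 nM, with a plausible range from 600 nM to 10000 nM.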

Compound 3, half-maximal inhibitory concentration: 5000 nM
Beside the measured number, compound 3's estimate is 2.0-fold (0.30 log units) below it; low and high end bracket the measured number.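

In this assay, putting dimethylamino in place of fluoro on the aromatic carbon para to a large group gives a 2.5-fold higher number from compound 2 to compound 3 (0.40 log units; beyond the scatter) and so weaker inhibition, a modest step that lies beyond the scatter. Among the compounds shown here, this is the first sign that the reading responds to what sits at this position, since turning 4-fluorobenzyl into 4-(dimethylamino)benzyl is the only difference between the two compounds. No measurement shown here accounts for the shift, so it cannot be tied to any particular feature of either group.

A single step gives a direction for one swap only, and it cannot show whether the trend extends to other groups at this position. A plain amine, a methoxy group or a carboxylic acid on the same carbon could each land on either side of compound 2, and compound 1 offers no comparison without a reported result.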